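Adding a methyl to the phenyl of compound 2

The compounds below may be only part of what the source reports. "The series", "measured", "known", "first", "only" and "open" are said of these compounds alone.

Compound 1 `C=CCn1c(N)c(C#N)c2c(N)ncnc21`: > 100000 nM (a limit of the assay)
Compound 2 `N#Cc1c(N)n(Cc2ccccc2)c2ncnc(N)c12`: 34000 nM
Compound 3 `Cc1ccc(Cn2c(N)c(C#N)c3c(N)ncnc32)cc1`: not yet measured

Among the measured compounds shown here, in a functional assay on KB cells (Homo sapiens) for inhibition (a higher number here means a weaker inhibitor, a lower number a stronger inhibitor), compound 2 gives 34000 nM, the only exact number so far. Compound 1 reads > 100000 nM, which is a limit of the assay and not a number. Compound 2 therefore has no exact value to be ranked against.

Compound 3 keeps everything in compound 2 except for one change on the phenyl: methyl in place of hydrogen on an aromatic carbon, para to a large group (methyl in place of hydrogen on an aromatic carbon). For the measured compounds named here, one measured step bears on this, an at least 2.9-fold lower number from compound 1 to compound 2 (0.46 log units; beyond the scatter), which put phenyl in place of vinyl. It concerns the same side group but a much larger replacement, and one end of it is a limit, so it offers only a loose guide. Adding a single methyl to that phenyl is a smaller edit, so no clear shift is expected in this assay. The expected outcome is a 1.1-fold lower number from compound 2 to compound 3 (0.05 log units; within the scatter). For compound 3 the estimate is 30000 nM, with an expected range of 10000 nM to 90000 nM.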

Compound 3, half-maximal inhibitory concentration: > 100000 nM
Compound 3 gave a limit, no number; the forecaster's own chance of this, stated with the estimate: 15%; at least 3.3-fold (0.52 log units) between middle value and limit.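

Among the compounds shown here, until now, the only measured change in this side group was phenyl in place of vinyl, which went with a lower number in this assay. The new step shows that the phenyl itself does not tolerate every addition, since a single methyl on an aromatic carbon, para to a large group, gives an at least 2.9-fold higher number from compound 2 to compound 3 (0.46 log units; beyond the scatter). Compound 3 reads > 100000 nM, which is a limit of the assay and not a number. The step from compound 1 to compound 3 cannot be read, because both of its ends are limits: the limit of > 100000 nM in this assay, at which 2 of the 3 values shown sit.

On these data alone, whether any small group on that same aromatic carbon goes with a higher number, or only methyl does, stays open, and a fluorine, a hydroxyl or a methoxy there would speak to this. The compounds shown also leave open how far the true number of compound 3 lies from that of compound 2, and whether a longer chain carrying the phenyl would read lower than compound 2.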